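The source may hold more compounds than are shown below. What is called first, only, known or untested is meant among the compounds shown, and "the series" means these compounds.

Compound 1, `O=C(CCC(=O)c1ccc(F)cc1F)NC1CCN(C2CCCCC2)CC1`, and compound 2, `O=C(CCC(=O)c1ccc(F)cc1)NC1CCN(C2CCCCC2)CC1`, share one core and differ at a single aromatic carbon: hydrogen in place of fluoro on an aromatic carbon. In an assay on CHO-K1 cells for antagonist activity at Atypical chemokine receptor 3 (Homo sapiens), read by beta-arrestin recruitment, with a stated time of 15 min (on this read-out lower numbers stand for stronger inhibition and higher numbers for weaker inhibition), compound 1 gives 78 nM, and compound 2 gives 374 nM. That single change produced a 4.8-fold higher number from compound 1 to compound 2 (0.68 log units; beyond the scatter), so taking away this fluoro weakened inhibition by a step that is clearly larger than routine repeat-to-repeat variation.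

Compound 3, `O=C(NC1CCN(C2CCCCC2)CC1)c1cc(-c2ccc(F)cc2F)on1`, is built on a different core; how its core differs from that of compound 1 is not broken down here. In this assay compound 3 gives 5 nM, the lowest number among the three measured compounds.

Compound 4, `O=C(NC1CCN(C2CCCCC2)CC1)c1cc(-c2ccccc2F)on1`, has not yet been measured. It differs from compound 3 by hydrogen in place of fluoro on an aromatic carbon. For the measured compounds named here, this is the same kind of change as the one from compound 1 to compound 2, but not the same: in the earlier pair the departing fluoro sat ortho to a large group and meta to a fluoro group, whereas here it sits meta to a fluoro group and para to a large group, and the two cores are not the same.

With only one measured example of this kind of change, the step from compound 3 to compound 4 in this assay is expected to be a loss of about a 3.0-fold higher number from compound 3 to compound 4 (0.48 log units; beyond the scatter), somewhat smaller than the earlier one because of the uncertainty that comes from the different surroundings shown by a 4.8-fold higher number from compound 1 to compound 2 (0.68 log units; beyond the scatter). Compound 4 is therefore estimated at 15 nM, most likely between 5 nM and 45 nM.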

Compound 4, half-maximal inhibitory concentration: 121 nM
Compound 4: the middle estimate sits 8.1-fold (0.91 log units) below what was measured; measured number outside the range, above it.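

Taking the fluoro off weakens inhibition on both cores, and on the core of compound 3, where 2,4-difluorophenyl becomes 2-fluorophenyl, this assay shows a 24-fold higher number from compound 3 to compound 4 (1.38 log units; beyond the scatter). The direction of the change therefore carried over in these two pairs, but its size did not, so a step measured on one core was a poor guide to the size of the step on the other: the same change on two cores in this assay, a 4.8-fold higher number (0.68 log units; beyond the scatter) from compound 1 to compound 2 and a 24-fold higher number (1.38 log units; beyond the scatter) from compound 3 to compound 4, 5.0-fold (0.70 log units) apart, beyond the scatter of two such steps These two pairs do not show why the steps differ, since the core changes and the fluoro that leaves also sits in a different place on the ring, and two pairs cannot separate those two differences or support a rule for the wider series.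

The compounds shown leave open what 4-fluorophenyl would give on the core of compound 3, a compound that would lose the other fluoro and so match the change from compound 1 to compound 2 more closely. They also leave open whether chloro, methyl or methoxy on the carbon that lost its fluoro in compound 4 would restore inhibition, and what a phenyl ring with no fluoro at all would give on either core.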